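A few compounds are considered here, and "the series" means these few. Any claim that something is new, unique, unknown or untested is made for them only; others in the source may bear on it.

Compound 1, `O=C(Nc1ccc(S(=O)(=O)Nc2ccccc2)cc1)c1ccc(Cl)nc1F`, gives 2290 nM in a functional assay on HEK293 cells for agonist activity at probable G-protein coupled receptor 27 (Homo sapiens), read by a luciferase reporter and beta-arrestin recruitment, with a stated time of 10 min; on this read-out lower numbers stand for an effect already at smaller amounts and higher numbers for an effect only at larger amounts of compound.
Compound 3, `CN(c1ccccc1)S(=O)(=O)c1ccc(NC(=O)c2ccc(Cl)cc2Cl)cc1`, gives 2570 nM in this assay.
Compound 2, `O=C(Nc1ccc(S(=O)(=O)Nc2ncccn2)cc1)c1ccc(Cl)cc1Cl`, returns in this assay only a limit, > 100000 nM.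

Among the two numbers given, compound 1 holds the lower one, but compound 3 sits within the scatter of it, so no order between the two can be read. Compound 2 stands at the limit of > 100000 nM in this assay, at which 1 of the 3 values shown sits.

Among the measured compounds shown here, the only step between compounds that differ in one place is an at least 38-fold lower number from compound 2 to compound 3 (1.59 log units; beyond the scatter); it concerns the group on the sulfonyl sulfur, not the carbonyl side. Compound 4, `Cc1cc(Br)ccc1C(=O)Nc1ccc(S(=O)(=O)Nc2ccccc2)cc1`, differs from compound 1 elsewhere: 4-bromo-2-methylphenyl in place of 6-chloro-2-fluoropyridin-3-yl on a carbonyl carbon. For the measured compounds named here, no measured step addresses that side of the shared core. Compound 1 and compound 3 differ in two places at once, so their values show only that changing both the carbonyl-side aryl and the group on the sulfonyl sulfur left the number within the scatter.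

With nothing pointing either way, the step from compound 1 to compound 4 is expected to be a 1.1-fold higher number from compound 1 to compound 4 (0.04 log units; within the scatter). Compound 4 is therefore estimated at 2500 nM, likely between 600 nM and 12000 nM.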

Compound 4, half-maximal effective concentration: 851 nM
Beside the measured number, compound 4's estimate is 2.9-fold (0.47 log units) above it; the range from low to high includes it.
By their numbers in this assay, from the lowest: compound 4; then compounds 1 and 3 (each within the scatter of the next). At a limit, above all of these: compound 2.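

At the carbonyl carbon, the aryl group proves able to move the number in this assay: with the phenylamino group on the sulfonyl sulfur kept the same, 4-bromo-2-methylphenyl in place of 6-chloro-2-fluoropyridin-3-yl gives a 2.7-fold lower number from compound 1 to compound 4 (0.43 log units; beyond the scatter). Among the compounds shown here, this is the first step on this side of the shared core, as the only earlier step concerned the group on the sulfonyl sulfur. Nothing given here offers a reason for the step.

As far as these compounds go, the whole aryl group changed at once, so it stays open whether the bromine, the methyl group, or the loss of the ring nitrogen, fluorine or chlorine carries the step. Also open, from the compounds shown here alone, is how a plain phenyl, or a phenyl bearing a methoxy group or a carboxylic acid, would read at this position.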